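The source may hold more compounds than are shown below. What is called first, only, known or untested is meant among the compounds shown, and "the series" means these compounds.

In a functional assay on K562 cells (Homo sapiens) for cytotoxicity, read by XTT assay, with a stated time of 24 h (on this read-out lower numbers stand for stronger inhibition and higher numbers for weaker inhibition), compound 1 `COc1ccc(C(=O)Nc2ccc(C)c(Nc3nccc(-c4cccnc4)n3)c2)cc1OCCCCn1ccnc1` gives 10100 nM. Compound 2 `Cc1ccc(NC(=O)c2ccc(OCCCCn3ccnc3)cc2)cc1Nc1nccc(-c2cccnc2)n1` gives 49900 nM, the higher of the two numbers and so the weaker result, with a gap beyond the usual scatter. Compound 3 `Cc1ccc(NC(=O)c2ccc(OCCCCn3ccnc3)c(I)c2)cc1Nc1nccc(-c2cccnc2)n1` has not yet been measured. It differs from compound 2 by iodo in place of hydrogen on an aromatic carbon, with iodo in place of hydrogen on an aromatic carbon. Going by the values given here, no measured pair shows what this change does, so only a modest shift toward stronger inhibition is expected, an estimated 2.0-fold lower number from compound 2 to compound 3 (0.30 log units; within the scatter). For compound 3 the expected value is 25000 nM, with an estimated range of 8000 nM to 70000 nM.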

Compound 3, half-maximal inhibitory concentration: 32500 nM
Compound 3: the middle estimate sits 1.3-fold (0.11 log units) below what was measured; the measured number falls inside the stated range.
By their numbers in this assay, from the lowest: compound 1; then compounds 3 and 2 (each within the scatter of the next).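

In this assay, iodo in place of hydrogen on the aromatic carbon ortho to the 4-(1H-imidazol-1-yl)butoxy group gives a 1.5-fold lower number from compound 2 to compound 3 (0.19 log units; within the scatter). Going by these compounds alone, this is the first direct reading of the change, and it shows that adding this single iodine atom at this position does not shift the result beyond the usual scatter. As far as these compounds go, whether a smaller halogen such as fluoro or chloro, or an amine or a carboxylic acid, would behave in the same way at this position remains open. No measurement shown here offers an explanation for this result.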